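Removing the thiazolyl group from a sulfonylcarbamate biphenyl series

The source may report more compounds than this note shows. Statements on the series, on what has been measured and on what is new or still open speak of the compounds shown alone.

Compound 1 `CCCCOC(=O)NS(=O)(=O)c1ccc(CCC)cc1-c1ccc(Cn2c(-c3nccs3)nc3ccccc32)cc1` has been tested in an assay on membranes from HEK293 cells for displacement of a labelled ligand from Type-2 angiotensin II receptor (Homo sapiens), read by radioligand binding (on this read-out lower numbers stand for stronger inhibition and higher numbers for weaker inhibition), where compound 1 gives 5.1 nM. Two related compounds have also been measured. Compound 2 `CCCc1ccc(S(=O)(=O)NC(=O)OCCCC(F)(F)F)c(-c2ccc(Cn3c(C(C)(C)C)nc4ccccc43)cc2)c1` gives 4.5 nM in this assay, a number within the scatter of that of compound 1. Compound 3 `CCCCOC(=O)NS(=O)(=O)c1ccc(CCC)cc1-c1cc(F)c(Cn2c(C(C)(C)C)nc3ccccc32)c(F)c1` gives 11 nM, a number that lies beyond the scatter above compound 1, so compound 1 holds the second highest of the three values. Compound 4 `CCCCOC(=O)NS(=O)(=O)c1ccc(CCC)cc1-c1ccc(Cn2cnc3ccccc32)cc1` awaits measurement; it differs from compound 1 by hydrogen in place of 1,3-thiazol-2-yl on an aromatic carbon. Among the compounds with values here, no measured pair shows this change, so its size is uncertain; a rise in the number beyond the scatter is expected, estimated as a 5.9-fold higher number from compound 1 to compound 4 (0.77 log units; beyond the scatter). Compound 4 is expected to give 30 nM in this assay, within a range from 8 nM to 120 nM.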

Compound 4, inhibition constant: 29 nM
Estimate against measurement, compound 4: 1.0-fold (0.01 log units) above; the range from low to high includes it.
By their numbers in this assay, from the lowest: compounds 2 and 1 (each within the scatter of the next); then compound 3; then compound 4.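

The position between two ring nitrogen atoms now has its first single-place comparison: in this assay there is a 5.7-fold higher number from compound 1 to compound 4 (0.75 log units; beyond the scatter) when hydrogen replaces 1,3-thiazol-2-yl on that aromatic carbon. So the group at this place counts for the number, yet even with no heavy atom there compound 4 gives 29 nM in this read-out. Nothing at hand accounts for the step.

From the compounds shown here alone, whether a methyl group, a phenyl ring or an amine on this carbon would bring the number back toward that of compound 1 stays open. Compounds 2 and 3 differ from compound 1 in more than one place and cannot settle this.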